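The compounds below may be only part of what the source reports. "The series", "measured", "known", "first", "only" and "open" are said of these compounds alone.

Compound 2 `N/C(=N\O)c1cn(COC(CO)CO)c2ncnc(N)c12` is one of three measured members of a small series built on a shared core. Compound 1 `N#Cc1cn(COC(CO)CO)c2ncnc(N)c12` carries a nitrile where compound 2 carries its larger group. In an ADME assay on cells (kidney, Cercopithecidae) for cytotoxicity (a lower number here means a stronger inhibitor, a higher number a weaker inhibitor), compound 1 gives > 100000 nM, which is a limit of the assay rather than a number. In this assay compound 2 gives > 100000 nM, again a limit. Compound 3 `N#Cc1cn(C(CO)OC(CO)CO)c2ncnc(N)c12` carries a hydroxymethyl in place of hydrogen on the chain. In this assay compound 3 gives > 100000 nM, also only a limit. Compound 2 therefore stands at the limit of > 100000 nM in this assay, at which 3 of the 3 values shown sit, with no number of its own to set it apart. Compound 4 `Nc1ncnc2c1ccn2COC(CO)CO` has not yet been measured. It differs from compound 2 by a hydrogen atom in place of a group of 4 heavy atoms (1 carbon, 2 nitrogen, 1 oxygen; no ring), on an aromatic carbon. Among the measured compounds shown here, two measured steps touch this part of the series, a step that the two limits leave unreadable from compound 1 to compound 2 and a step that the two limits leave unreadable from compound 1 to compound 3; both join values that are limits, so neither has a readable size. Nothing in these three results points to a change beyond the scatter in either direction. For compound 4 the expected value in this assay is 100000 nM, with a range from 30000 nM to 300000 nM. The expected step is a number no higher from compound 2 to compound 4 (the limit leaves the size open), and most likely the assay will again report only a limit.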

Compound 4, half-maximal inhibitory concentration: > 100000 nM
Compound 4 ended at the assay's limit (the forecaster's own chance of this, stated with the estimate: 85%); the middle value sits exactly at the limit.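

In this assay compound 4 gives > 100000 nM, again a limit and not a number. Its steps from compound 1 and from compound 2 therefore cannot be read, and all four compounds share one result: the limit of > 100000 nM in this assay, at which 4 of the 4 values shown sit. The compounds shown leave open at what concentration, if any, each would harm these cells, and whether the four differ at all.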